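This account rests on a few compounds, and the source may have more. Where it says the series, first, only, none or still open, it means among the compounds named here.

Compound 1 `COc1ccc(-c2nc(/N=C(\N)NC(C)C)sc2-c2ccc(OC)cc2)cc1` gives 9.1 uM in a functional assay (aorta) with Rattus norvegicus as the target; on this read-out lower numbers stand for an effect already at smaller amounts and higher numbers for an effect only at larger amounts of compound.
Compound 2 `C/N=C(/NC)Nc1nc(-c2ccc(OC)cc2)c(-c2ccc(OC)cc2)s1` gives 2.4 uM in this assay.

Going by the values given here, of the two numbers, compound 1 stands as the higher one, and the only measured step between them, a 3.8-fold lower number from compound 1 to compound 2 (0.58 log units; beyond the scatter), alters the group on an aromatic carbon of the shared core while keeping hydrogen-bond donors there. Compound 3 `CCN(CC)C(=O)c1nc(-c2ccc(OC)cc2)c(-c2ccc(OC)cc2)s1` has not yet been measured. It differs from compound 1 in one place: a group of 7 heavy atoms (5 carbon, 1 nitrogen, 1 oxygen; no ring) in place of a group of 7 heavy atoms (4 carbon, 3 nitrogen; no ring), on an aromatic carbon. The entering diethylcarbamoyl carries no hydrogen-bond donor, so the measured step bears on the present one only loosely: it shows that the number can move when this position is changed, but nothing measured shows what happens when the donors are removed. The expectation therefore leans toward a higher number, with wide uncertainty. The estimate for compound 3 is 20 uM, with a range from 5 uM to 80 uM. The expected step, a 2.2-fold higher number from compound 1 to compound 3 (0.34 log units; beyond the scatter), is judged to lie beyond the scatter, though a result within it would not be surprising.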

Compound 3, concentration for half-maximal effect: 14 uM
Compound 3: middle estimate off by 1.4-fold (0.15 log units), on the high side; the range from low to high includes it.
By their numbers in this assay, from the lowest: compound 2; then compounds 1 and 3 (each within the scatter of the next).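

At this position, the step (a 1.5-fold higher number from compound 1 to compound 3 (0.19 log units; within the scatter)) shows that in this assay the hydrogen-bond donors of the leaving group are not needed for a number in this range, as diethylcarbamoyl, with 0 hydrogen-bond donors, cannot be told apart from the group of compound 1. The same entering group does separate clearly from the group of compound 2 (a 5.8-fold higher number from compound 2 to compound 3 (0.77 log units; beyond the scatter)), so the lower number of compound 2 does not come simply from having hydrogen-bond donors at this position, and compound 1, which also has them, goes against any such rule. Nothing measured here accounts for these differences.

The compounds shown leave open how a primary amine or a carboxylic acid on this aromatic carbon would read in this assay, and whether dimethylcarbamoyl, with its shorter chains, would stay level with diethylcarbamoyl. They also leave open what the two 4-methoxyphenyl groups contribute, since both stay the same in all three compounds.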